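Replacing tert-butyl with difluoromethoxy: compound 3 to compound 4

The source may hold more compounds than are shown below. What is called first, only, known or untested is meant among the compounds shown, and "the series" means these compounds.

Compound 1 `Cc1ccc(NS(=O)(=O)c2ccc(N3CCNC3=O)cc2)cc1` gives 480 nM
Compound 2 `O=C1NCCN1c1ccc(S(=O)(=O)Nc2ccccc2)cc1` gives 280 nM
Compound 3 `CC(C)(C)c1ccc(NS(=O)(=O)c2ccc(N3CCNC3=O)cc2)cc1` gives > 1000 nM

These readings come from a functional assay on HT-29 cells (Homo sapiens) for antiproliferative activity, read by sulforhodamine B assay, with a stated time of 48 h (on this read-out higher numbers stand for weaker inhibition and lower numbers for stronger inhibition), and all share one core. For compound 3 the reading > 1000 nM is a limit of this assay and not a number. On these data alone, compound 3 therefore stands at the limit of > 1000 nM in this assay, at which 1 of the 3 values shown sits, and its true value stays open.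

Compound 4 `O=C1NCCN1c1ccc(S(=O)(=O)Nc2ccc(OC(F)F)cc2)cc1` carries difluoromethoxy in place of tert-butyl on an aromatic carbon, para to a large group, and the count of the change reads difluoromethoxy in place of tert-butyl on an aromatic carbon with the rest of the structure kept.

Going by the values given here, two measured steps bear on this by bringing tert-butyl in. Tert-butyl in place of methyl gave an at least 2.0-fold higher number from compound 1 to compound 3 (0.31 log units; beyond the scatter) and tert-butyl in place of hydrogen gave an at least 3.5-fold higher number from compound 2 to compound 3 (0.55 log units; beyond the scatter) and both are at least modest. Hydrogen in place of methyl gave a 1.7-fold lower number from compound 1 to compound 2 (0.23 log units; within the scatter) and so does not separate the two smaller cases. Among the compounds with values here, no measured step involves difluoromethoxy itself, so the guide is weak. Without tert-butyl, compound 4 is expected to read closer to compound 1 at 480 nM and compound 2 at 280 nM than to compound 3. The expected move is an at least 1.6-fold lower number from compound 3 to compound 4 (0.22 log units; that floor lies within the scatter) toward a lower number, and it is a modest one. The estimate for compound 4 is 600 nM with 250 nM to 1500 nM as the expected range.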

Compound 4, half-maximal inhibitory concentration: 650 nM
Beside the measured number, compound 4's estimate is 1.1-fold (0.03 log units) below it; low and high end bracket the measured number.
By their numbers in this assay, from the lowest: compounds 2, 1 and 4 (each within the scatter of the next, the first and the last beyond it). At a limit, above all of these: compound 3.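

In this assay, difluoromethoxy on this aromatic carbon, para to a large group, yields a measured number where tert-butyl did not, with an at least 1.5-fold lower number from compound 3 to compound 4 (0.18 log units; that floor lies within the scatter), though that floor alone does not establish a change beyond the scatter. The reading for compound 3 is a limit of the assay and not a number, so the full size of this step stays unknown: the limit of > 1000 nM in this assay, at which 1 of the 4 values shown sits.

Set against the other two groups at this position, difluoromethoxy gives a 1.4-fold higher number from compound 1 to compound 4 (0.13 log units; within the scatter), which is within the scatter, and a 2.3-fold higher number from compound 2 to compound 4 (0.37 log units; beyond the scatter), which is beyond it, so among the three compounds with measured numbers, only the comparison with hydrogen separates difluoromethoxy from a smaller case.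

The compounds shown leave open how an amine, a carboxylic acid or a single chlorine atom at this position would read, since all four groups here are hydrogen, methyl, tert-butyl and difluoromethoxy. They also leave open whether methoxy would read like difluoromethoxy, which would show whether the fluorine atoms matter here at all.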